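The compounds below may be only part of what the source reports. "The series", "measured", "known", "first", "only" and "open" are said of these compounds alone.

Working notes on the series:

- Compound 1 `CN1C/C(=C\c2cccc([N+](=O)[O-])c2)C(=O)/C(=C/c2ccccc2F)C1`: 2340 nM
- Compound 2 `COc1cc(/C=C2\CN(C)C/C(=C\c3ccc(Cl)c(Cl)c3)C2=O)cc(OC)c1`: 6900 nM
- Compound 3 `COc1cc(/C=C2\CN(C)C/C(=C\c3ccc(Cl)cc3Cl)C2=O)cc(OC)c1OC`: > 20000 nM (a limit, not a number)

Within the data shown here, in a functional assay on HeLa cells (Homo sapiens) for cytotoxicity, read by MTT assay, with a stated time of 24 h (a higher number here means a weaker inhibitor, a lower number a stronger inhibitor), compound 1 gives 2340 nM, the lower of the only two numbers in hand. The nearest neighbour is compound 2 at 6900 nM, a gap beyond the usual scatter. Compound 3 sits at the limit of the assay, with > 20000 nM.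

The next compound is compound 4 `CN1C/C(=C\c2cccc([N+](=O)[O-])c2)C(=O)/C(=C/c2ccc(Cl)c(Cl)c2)C1`. It differs from compound 1 in one place: 3,4-dichlorophenyl in place of 2-fluorophenyl on a double-bonded chain carbon bound to a double-bonded ring carbon. Among the measured compounds shown here, no measured pair isolates this change, so the expectation rests on thin ground. Compound 2 also carries the 3,4-dichlorophenyl group and gives 6900 nM, but it differs from compound 4 elsewhere, which supports only a slight lean towards a higher number. In this assay, no change beyond the scatter is expected, and the estimated step is a 1.3-fold higher number from compound 1 to compound 4 (0.11 log units; within the scatter). For compound 4 the estimated value is 3000 nM, with an expected range of 1000 nM to 9000 nM.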

Compound 4, half-maximal inhibitory concentration: 9120 nM
For compound 4 the middle estimate is 3.0-fold (0.48 log units) below the measured one, outside the stated range (above it).
By their numbers in this assay, from the lowest: compound 1; then compounds 2 and 4 (each within the scatter of the next). At a limit, above all of these: compound 3.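

Among these compounds, this is the first one-place comparison at this position, on a double-bonded chain carbon bound to a double-bonded ring carbon. In this assay, 3,4-dichlorophenyl in place of 2-fluorophenyl gives a 3.9-fold higher number from compound 1 to compound 4 (0.59 log units; beyond the scatter), with the rest of the core of compound 1 unchanged. The position therefore responds to the identity of the aryl group in this cytotoxicity read-out, and of these two groups the 2-fluorophenyl goes with the lower number, though this rests on a single modest step from one matched pair. No measurement in hand bears on why the step arises.

The step changes the halogen, its number and its placing on the ring together, so it cannot separate the loss of the 2-fluorophenyl group from the arrival of the 3,4-dichlorophenyl group, and a plain phenyl at this place would be the reference that divides the two. Also open, as far as these compounds go, are whether a 4-dimethylaminophenyl or a pyridyl group at this place would move the number in either direction, and whether the step keeps its size when the group on the other side of the core is different.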